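This account rests on a few compounds, and the source may have more. Where it says the series, first, only, none or still open, it means among the compounds named here.

The measured compounds:
Compound 1 `Cc1cccc(-n2nncc2CN2C(=O)C3(C(C#N)=C(N)Oc4c3c3nc5ccccc5nc3c3ccccc43)c3ccccc32)c1` gives in an ADME assay on L02 cells (Homo sapiens) for antiproliferative activity, read by MTT assay, with a stated time of 48 h (a higher number here means a weaker inhibitor, a lower number a stronger inhibitor), a limit, > 50000 nM.
Compound 2 `N#CC1=C(N)Oc2c(c3nc4ccccc4nc3c3ccccc23)C12C(=O)N(Cc1cnnn1-c1cc(Cl)ccc1Cl)c1ccccc12` gives in this assay a limit, > 50000 nM.
Compound 3 `N#CC1=C(N)Oc2c(N)cc3nc4ccccc4nc3c2C12C(=O)N(Cc1cnnn1-c1ccc(F)cc1)c1ccccc12` gives in this assay a limit, > 50000 nM.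

Compound 3 thus stands where every value shown stands: at the limit of > 50000 nM in this assay, at which 3 of the 3 values shown sit, which is a limit of the assay and not a number. Compound 4 `N#CC1=C(N)Oc2c(N)cc3nc4ccccc4nc3c2C12C(=O)N(Cc1cnnn1-c1cccc(C(F)(F)F)c1)c1ccccc12` differs from compound 3 in one place: 3-(trifluoromethyl)phenyl in place of 4-fluorophenyl on an aromatic nitrogen. No measured step bears directly on this change; the only step shown, a step that the two limits leave unreadable from compound 1 to compound 2, concerns a different pair and is left unreadable by its two limits. With nothing shown that moves any compound off the limit, compound 4 is expected to sit at 60000 nM, with a range from 30000 nM to 200000 nM. The step this implies, a step that the limit leaves unreadable from compound 3 to compound 4, is an estimate only.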

Compound 4, half-maximal inhibitory concentration: 38100 nM
Estimate against measurement, compound 4: 1.6-fold (0.20 log units) above, within the range that was stated.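

In this assay, 3-(trifluoromethyl)phenyl in place of 4-fluorophenyl on the aromatic nitrogen brings an at least 1.3-fold lower number from compound 3 to compound 4 (0.11 log units; that floor lies within the scatter), so this change is not shown to move the value beyond the scatter. Even so, compound 4 gives the first number here, showing that a compound with a group at this position can come off the limit that holds the others: the limit of > 50000 nM in this assay, at which 3 of the 4 values shown sit.

The step between the two limits of compound 1 and compound 2 cannot be read. From the compounds shown here alone, whether an amine or a carboxylic acid on this phenyl ring would shift the number remains open.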